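This account rests on a few compounds, and the source may have more. Where it says the series, first, only, none or still open, it means among the compounds named here.

Series overview, cytotoxicity in a functional assay on KB cells (Homo sapiens) for cytotoxicity, read by resazurin assay, with a stated time of 3 days; on this read-out higher numbers stand for weaker inhibition and lower numbers for stronger inhibition:

compound 1, `CC(C)(CNC(=O)c1ccccc1O)CC1=C(O)C(=O)c2ccccc2C1=O`: 44900 nM
compound 2, `CC(C)(CNC(=O)c1ccc2ccccc2c1)CC1=C(O)C(=O)c2ccccc2C1=O`: 9000 nM
compound 3, `COC1=C(CC(C)(C)CNC(=O)c2ccc3ccccc3c2)C(=O)c2ccccc2C1=O`: 34100 nM

Compound 2 holds the lowest number of the three in this assay, and both neighbours sit beyond the scatter from it. Swapping the aryl group on the carbonyl carbon gave a 5.0-fold lower number from compound 1 to compound 2 (0.70 log units; beyond the scatter), while capping the hydroxyl of the core gave a 3.8-fold higher number from compound 2 to compound 3 (0.58 log units; beyond the scatter).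

Compound 4, `COc1c(C(=O)NCC(C)(C)CC2=C(O)C(=O)c3ccccc3C2=O)ccc2ccccc12`, is not yet measured. Its difference from compound 2 is methoxy in place of hydrogen on an aromatic carbon, the new group sitting on an aromatic carbon of a six-membered aromatic ring of carbon only, part of a fused or bridged system of two rings, ortho to a fused ring and ortho to a large group. Within the data shown here, neither measured step touches that ring position: the step from compound 1 to compound 2 exchanges the whole aryl group and the step from compound 2 to compound 3 alters the core, so no step in hand speaks directly to a methoxy on the naphthalenyl ring. With the core and amide of compound 2 retained, no step beyond the scatter is expected in this assay, with a slight lean toward a higher number. The estimated step is a 1.3-fold higher number from compound 2 to compound 4 (0.12 log units; within the scatter). Compound 4 is expected to give about 12000 nM, within roughly 5000 nM to 30000 nM.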

Compound 4, half-maximal inhibitory concentration: 66900 nM
Beside the measured number, compound 4's estimate is 5.6-fold (0.75 log units) below it; the whole stated range lies below it.
By their numbers in this assay, from the lowest: compound 2; then compounds 3, 1 and 4 (each within the scatter of the next).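

Methoxy in place of hydrogen on an aromatic carbon of the naphthalenyl ring, ortho to a fused ring and ortho to a large group, gives a 7.4-fold higher number from compound 2 to compound 4 (0.87 log units; beyond the scatter) in this assay, so this single added group moves the number beyond the scatter although the core and amide of compound 2 stay unchanged. The earlier steps shown here showed only that exchanging the whole aryl group and capping the hydroxyl of the core matter; this one shows that the naphthalenyl ring is also sensitive to a small substitution at this position, and in the direction of weaker inhibition, leaving compound 2 with the lowest number. No measurement at hand bears on why this position responds in this way.

On these data alone, whether the higher number belongs to methoxy itself or would follow any group at this place stays open, for instance a chlorine atom, an amine or a longer ethoxy chain on the same aromatic carbon. Also open, as far as these compounds go, is whether methoxy on other carbons of the naphthalenyl ring would give a step of similar size and direction.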